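Chloro to Methyl on the Pendant Phenyl Ring

A few compounds are considered here, and "the series" means these few. Any claim that something is new, unique, unknown or untested is made for them only; others in the source may bear on it.

Compound 2 `C/C(=N\Nc1nc(-c2ccc(Cl)cc2)cs1)c1cc2ccccc2o1` is tested in a functional assay on HepG2 cells (Homo sapiens) for antiproliferative activity (on this read-out higher numbers stand for weaker inhibition and lower numbers for stronger inhibition), where compound 2 gives 23200 nM. Compound 1 `C/C(=N\Nc1nc(-c2ccc(Br)cc2)cs1)c1cc2ccccc2o1` gives 27700 nM in this assay, and the two values lie within the scatter of each other, so neither stands apart. Compound 3 `C/C(=N\Nc1nc(-c2ccc(C)cc2)cs1)c1cc2ccccc2o1` differs from compound 2 by methyl in place of chloro on an aromatic carbon, para to a large group, as in 4-chlorophenyl to 4-methylphenyl. Among the compounds with values here, the only measured step, a 1.2-fold lower number from compound 1 to compound 2 (0.08 log units; within the scatter), swaps one halogen for another and stays within the scatter; it bears on this change only loosely. The move to compound 3 is therefore expected to be small, a 1.1-fold higher number from compound 2 to compound 3 (0.03 log units; within the scatter). Compound 3 is estimated at 25000 nM, within 10000 nM to 60000 nM.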

Compound 3, half-maximal inhibitory concentration: 14100 nM
Compound 3: middle estimate off by 1.8-fold (0.25 log units), on the high side, and the stated range covers the measured number.
By their numbers in this assay, from the lowest: compounds 3, 2 and 1 (each within the scatter of the next).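

In this assay the position now holds a carbon group as well as two halogens: methyl for chloro gives a 1.6-fold lower number from compound 2 to compound 3 (0.22 log units; within the scatter) and methyl for bromo gives a 2.0-fold lower number from compound 1 to compound 3 (0.29 log units; within the scatter) on the same ring position. Both steps stay within the scatter, so swapping either halogen for methyl shows no real change here. Nothing available explains these small differences.
The compounds shown leave open whether an amine, a carboxylic acid or a longer chain at this position would move the number beyond the scatter.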